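Removing the Methylsulfonyl Group from a Weak Antiproliferative Amide

The compounds below may be only part of what the source reports. "The series", "measured", "known", "first", "only" and "open" are said of these compounds alone.

Compound 3 `CS(=O)(=O)c1ccc(C(=O)Nc2ccc(Cl)c(-c3nnc4c(Cl)cccn34)c2)c(Cl)c1` carries a methylsulfonyl group on one of its aromatic rings. In a functional assay on MCF7 cells (Homo sapiens) for antiproliferative activity, read by MTT assay, with a stated time of 72 h (on this read-out higher numbers stand for weaker inhibition and lower numbers for stronger inhibition), compound 3 gives only a limit, > 100000 nM. Its two neighbours in the series are compound 1 `Cc1cc(Cl)ccc1C(=O)Nc1ccc(Cl)c(-c2nnc3c(Cl)cccn23)c1` and compound 2 `O=C(Nc1ccc(Cl)c(-c2nnc3c(Cl)cccn23)c1)c1ccc(Cl)cc1Cl`. Compound 1 likewise gives only a limit, > 100000 nM. Compound 2 gives 78200 nM. The step of an at least 1.2-fold lower number from compound 1 to compound 2 (0.10 log units; that floor lies within the scatter) and the step of an at least 1.2-fold higher number from compound 2 to compound 3 (0.10 log units; that floor lies within the scatter) are both floored by the limit of > 100000 nM in this assay, at which 2 of the 3 values shown sit, so neither says more than that compound 2 sits near the same weak level as its two partners. Compound 4 `O=C(Nc1ccc(Cl)c(-c2nnc3c(Cl)cccn23)c1)c1ccccc1Cl` differs from compound 3 by hydrogen in place of methylsulfonyl on an aromatic carbon. For the measured compounds named here, no measured step removes a group at this position outright, and the two steps that do touch this position stay within the scatter. Compound 4 is therefore expected to move by a number no higher from compound 3 to compound 4 (the limit leaves the size open), which is no step beyond the scatter. The estimate for compound 4 in this assay is 100000 nM, within 30000 nM to 300000 nM, with a real chance that only a limit is reported again.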

Compound 4, half-maximal inhibitory concentration: 92200 nM
For compound 4 the middle estimate is 1.1-fold (0.04 log units) above the measured one; the measured number falls inside the stated range.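

In this assay compound 4, which carries only hydrogen on this aromatic carbon, gives a measured number, 92200 nM, so the position now has a reading without any substituent on it. The step that can be read in full is a 1.2-fold higher number from compound 2 to compound 4 (0.07 log units; within the scatter), which means that chloro and hydrogen on this carbon cannot be told apart in this read-out. The other two steps, an at least 1.0-fold lower number from compound 3 to compound 4 (0.03 log units; that floor lies within the scatter) and an at least 1.0-fold lower number from compound 1 to compound 4 (0.03 log units; that floor lies within the scatter), cannot be read, because each of them starts from a limit: the limit of > 100000 nM in this assay, at which 2 of the 4 values shown sit.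

The compounds shown leave open how far methylsulfonyl and hydrogen on this carbon really lie from each other. They also leave open whether an amine or a carboxylic acid at this position would give a step beyond the scatter.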